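This account rests on a few compounds, and the source may have more. Where it says the series, first, only, none or still open, it means among the compounds named here.

Compound 2 `COc1cccc(-n2c(-c3coc4cc(C)c(Cl)cc4c3=O)nc(-c3ccccc3)c2-c2ccccc2)c1` gives 6250 nM in a functional assay on A549 cells (Homo sapiens) for inhibition, read by MTT assay, with a stated time of 72 h (a higher number here means a weaker inhibitor, a lower number a stronger inhibitor), the lowest of the two numbers recorded so far. Going by the values given here, compound 1 `Cc1cc2occ(-c3nc(-c4ccccc4)c(-c4ccccc4)n3-c3cccc(Cl)c3)c(=O)c2cc1Cl` gives 25000 nM in this assay, and the step of a 4.0-fold lower number from compound 1 to compound 2 (0.60 log units; beyond the scatter), methoxy in place of chloro on an aromatic carbon, is the only measured step that can guide a forecast. Compound 3 `Cc1cc2occ(-c3nc(-c4ccccc4)c(-c4ccccc4)n3-c3ccc([N+](=O)[O-])cc3)c(=O)c2cc1Cl` has not yet been measured in this assay. It differs from compound 2 as follows: 4-nitrophenyl in place of 3-methoxyphenyl on an aromatic nitrogen. Among the compounds with values here, no measured step involves a 4-nitrophenyl group, so the bearing of the one measured step is indirect: it shows only that exchanging the group on the aryl ring shifts the number by a modest amount. Compound 3 is therefore expected to show a step of a 1.9-fold higher number from compound 2 to compound 3 (0.28 log units; within the scatter), a modest change of uncertain direction. The estimate for compound 3 is 12000 nM, with a range from 4000 nM to 35000 nM.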

Compound 3, half-maximal inhibitory concentration: 3130 nM
For compound 3 the middle estimate is 3.8-fold (0.58 log units) above the measured one; the measured number lies below the stated range.
By their numbers in this assay, from the lowest: compounds 3 and 2 (each within the scatter of the next); then compound 1.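

With 4-nitrophenyl on the aromatic nitrogen, the set gains a third aryl group at this place, and in this assay it reads level with 3-methoxyphenyl (a 2.0-fold lower number from compound 2 to compound 3 (0.30 log units; within the scatter)). Against 3-chlorophenyl the same exchange gives the largest step seen at this place so far (an 8.0-fold lower number from compound 1 to compound 3 (0.90 log units; beyond the scatter)), which leaves compound 1 apart from the other two, while compound 2 and compound 3 cannot be told apart. Nothing available explains how these aryl groups differ in their effect on the cells.

The compounds shown leave open whether the number follows the group on the phenyl ring or where on the ring it sits, and 3-nitrophenyl and 4-methoxyphenyl would separate the two. They also leave open how an amine or a carboxylic acid on this ring would read.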